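Compound 3 and a Repositioned Pyridine Nitrogen

The source may report more compounds than this note shows. Statements on the series, on what has been measured and on what is new or still open speak of the compounds shown alone.

Compound 1 `COc1ccc(-c2cccc(C(=O)N(C)C)c2)cc1S(=O)(=O)Nc1cccc(NCC(C)NC(=O)c2cccc(C)c2)c1` and compound 2 `COc1ccc(-c2cc(C(=O)N(C)C)ccn2)cc1S(=O)(=O)Nc1cccc(NCCNC(=O)c2cccc(C)c2)c1` were both tested in a functional assay on CHO-RD-HGA16 cells for agonist activity at Orexin/Hypocretin receptor type 1 (Homo sapiens), read by fluorescence and calcium flux, with a stated time of 30 min; a higher number here means a larger maximal response, a lower number a smaller maximal response. Compound 1 gives 94%, and compound 2 gives 93%; compound 2 has the lower of the two numbers, but its gap to compound 1 lies within the scatter. Compound 3 `COc1ccc(-c2cncc(C(=O)N(C)C)c2)cc1S(=O)(=O)Nc1cccc(NCCNC(=O)c2cccc(C)c2)c1` has not yet been measured. It differs from compound 2 in one place: 5-(dimethylcarbamoyl)pyridin-3-yl in place of 4-(dimethylcarbamoyl)pyridin-2-yl on an aromatic carbon. Among the measured compounds shown here, no step between measured compounds is available, and the two measured values sit close together, so the expected step is a number 3 percentage points lower from compound 2 to compound 3 (within the scatter), nothing beyond the scatter. Compound 3 is therefore estimated to give 90%, within a range from 72% to 105%.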

Compound 3, largest response reached (Emax), in percent of the reference or control that the assay uses: 105%
The estimate for compound 3 lay 15 percentage points below the measured number; the range from low to high includes it.
By their numbers in this assay, from the lowest: compounds 2 and 1 (each within the scatter of the next); then compound 3.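

At this aromatic carbon, para to a methoxy group, the arrangement of the same atoms matters in this assay: putting 5-(dimethylcarbamoyl)pyridin-3-yl in place of 4-(dimethylcarbamoyl)pyridin-2-yl gives a number 12 percentage points higher from compound 2 to compound 3 (beyond the scatter), though both groups count alike in heavy atoms, hydrogen-bond acceptors and charge. Compound 1 and compound 2 differ in more than one place and could not show this. No available evidence bears on this step. Going by these compounds, whether a nitrile or a carboxylic acid in place of the dimethylcarbamoyl group on this pyridine would keep the larger maximal response remains open.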